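Chloro to methyl on the anilino phenyl in a thiourea series

A few compounds are considered here, and "the series" means these few. Any claim that something is new, unique, unknown or untested is made for them only; others in the source may bear on it.

Compound 1 `Cc1ccc(NC(=S)NC(=O)c2cn(-c3ccccc3)nc2-c2ccc(Cl)cc2)cc1` gives 3120 nM in a functional assay on NCI-H460 cells (Homo sapiens) for inhibition, read by CCK-8 assay, with a stated time of 48 h; a higher number here means a weaker inhibitor, a lower number a stronger inhibitor. Compound 2 `Cc1ccc(NC(=S)NC(=O)c2cn(-c3ccccc3)nc2-c2ccc(C)cc2)cc1` gives 3760 nM in this assay. The change from compound 1 to compound 2 is methyl in place of chloro on an aromatic carbon, and the step it made is a 1.2-fold higher number from compound 1 to compound 2 (0.08 log units; within the scatter). Compound 3 `COc1ccc(-c2nn(-c3ccccc3)cc2C(=O)NC(=S)Nc2ccc(Cl)cc2)cc1` gives 3010 nM in this assay; its number and those of compound 1 and compound 2 all lie within the scatter of one another, so no order among the three is claimed. The difference between the core of compound 3 and the core of compound 1 is not broken down here.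

Compound 4 `COc1ccc(-c2nn(-c3ccccc3)cc2C(=O)NC(=S)Nc2ccc(C)cc2)cc1` has not been measured in this assay. It differs from compound 3 by methyl in place of chloro on an aromatic carbon, the same change that led from compound 1 to compound 2, at a place described in the same words. Going by the values given here, the expected step is therefore small: a 1.2-fold higher number from compound 3 to compound 4 (0.07 log units; within the scatter) is estimated for compound 4, resting on a 1.2-fold higher number from compound 1 to compound 2 (0.08 log units; within the scatter) seen in the one measured pair. Compound 4 is expected to give about 3500 nM in this assay, with a range from 1800 nM to 7000 nM.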

Compound 4, half-maximal inhibitory concentration: 2880 nM
The estimate for compound 4 lay 1.2-fold (0.08 log units) above the measured number, within the range that was stated.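

Methyl in place of chloro on an aromatic carbon gives steps in this assay that do not differ between the two cores: the same change on two cores in this assay, a 1.2-fold higher number (0.08 log units; within the scatter) from compound 1 to compound 2 and a 1.0-fold lower number (0.02 log units; within the scatter) from compound 3 to compound 4, 1.3-fold (0.10 log units) apart, within the scatter of two such steps. The new step, a 1.0-fold lower number from compound 3 to compound 4 (0.02 log units; within the scatter), stands with a 1.3-fold lower number from compound 2 to compound 4 (0.12 log units; within the scatter) and a 1.1-fold lower number from compound 1 to compound 4 (0.03 log units; within the scatter). All three lie within the scatter, and these numbers do not separate methyl, chloro and methoxy. Going by these compounds alone, this shows only that a step within the scatter stayed within it on these two cores; it does not show that a larger effect would carry over, and the change does not sit on the same group in both pairs, being on a 4-chlorophenyl group without the amino link from compound 1 to compound 2 and on the (4-chlorophenyl)amino group from compound 3 to compound 4.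

As far as these compounds go, whether any group at these places moves the number beyond the scatter remains open. An amine, a carboxylic acid or a longer chain in place of chloro would test this.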